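Aryl change from compound 3 to compound 4

The source may hold more compounds than are shown below. What is called first, only, known or untested is meant among the compounds shown, and "the series" means these compounds.

compound 1 `Cc1oc2c([C@H]3CCN(C)C[C@H]3O)c(O)cc(O)c2c(=O)c1C(O)c1ccc(F)c(Br)c1`: 14%
compound 2 `Cc1oc2c([C@H]3CCN(C)C[C@H]3O)c(O)cc(O)c2c(=O)c1C(O)c1csc([N+](=O)[O-])c1`: 20%
compound 3 `COc1ccc(C(O)c2c(C)oc3c([C@H]4CCN(C)C[C@H]4O)c(O)cc(O)c3c2=O)cc1Br`: 41%

In a functional assay on MCF7 cells (Homo sapiens) for inhibition, read by MTT assay, with a stated time of 48 h, tested at 10 uM (a lower number here means less inhibition of growth, a higher number more inhibition of growth at the concentration tested), compound 3 gives 41%, the highest of the three numbers, and both other compounds lie beyond the scatter from it. The two steps that reach it are a number 27 percentage points higher from compound 1 to compound 3 (beyond the scatter) and a number 21 percentage points higher from compound 2 to compound 3 (beyond the scatter), both modest. The remaining step, a number 6 percentage points higher from compound 1 to compound 2 (within the scatter), stays within the scatter.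

Compound 4 `Cc1oc2c([C@H]3CCN(C)C[C@H]3O)c(O)cc(O)c2c(=O)c1C(O)c1cc(F)cc(F)c1` carries 3,5-difluorophenyl in place of 3-bromo-4-methoxyphenyl on a saturated chain carbon bound to an aromatic carbon and an oxygen on a saturated carbon.

The closest evidence is a number 27 percentage points higher from compound 1 to compound 3 (beyond the scatter), where methoxy replaces fluoro on an aromatic carbon. Compound 4 has no methoxy and does carry fluoro, so that step is read here in reverse. The step of a number 21 percentage points higher from compound 2 to compound 3 (beyond the scatter) likewise shows a lower number for the other aryl group tried in compound 2. Among the measured compounds shown here, no measured step isolates the loss of bromine or the second fluoro, so the range stays wide.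

A modest fall is expected in this assay. The estimated step is a number 21 percentage points lower from compound 3 to compound 4 (beyond the scatter). For compound 4 the expected value is 20%, with an estimated range of 8% to 35%.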

Compound 4, percent growth inhibition at one concentration: 25%
Beside the measured number, compound 4's estimate is 5 percentage points below it; the range from low to high includes it.
By their numbers in this assay, from the lowest: compounds 1, 2 and 4 (each within the scatter of the next, the first and the last beyond it); then compound 3.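

In this assay, the place on a saturated chain carbon bound to an aromatic carbon and an oxygen on a saturated carbon now shows that an aryl group with neither bromine nor methoxy gives up part of the signal of compound 3: a number 16 percentage points lower from compound 3 to compound 4 (beyond the scatter), which leaves compound 3 highest of the four, beyond the scatter from each of the others. Fluoro on the aryl group does not fix the reading, since a number 11 percentage points higher from compound 1 to compound 4 (beyond the scatter), and the 3,5-difluorophenyl and 3-bromo-4-fluorophenyl groups thus stand apart even though both carry fluoro, while a number 5 percentage points higher from compound 2 to compound 4 (within the scatter) gives no separation between the 3,5-difluorophenyl and 5-nitrothiophen-3-yl groups. Nothing among the available data accounts for these differences between aryl groups.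

The compounds shown leave open whether methoxy or bromine carries the higher number of compound 3, as no aryl group here holds one of the two without the other. They also leave open how this place responds to a basic or acidic substituent, such as a dimethylamino group or a carboxylic acid on the phenyl ring.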